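The source may report more compounds than this note shows. Statements on the series, on what has been measured and on what is new or still open speak of the compounds shown alone.

Compound 1 `COc1ccc(-c2c(-c3ccc(OC)cc3)n(Cc3ccccc3)c3ncn(CCCO)c(=N)c23)cc1`: in an ADME assay for permeability, using PAMPA, with a stated time of 30 min, at pH 7.4 (on this read-out higher numbers stand for higher permeability and lower numbers for lower permeability), compound 1 reaches > 1000 10^-6 cm/s, which is a limit of the assay and not a number.
Compound 2 `COc1ccc(-c2c(-c3ccc(OC)cc3)n(Cc3ccccc3)c3ncn([C@H]4CC[C@H](OC)CC4)c(=N)c23)cc1`: in this assay compound 2 likewise reaches > 1000 10^-6 cm/s, again a limit.
Compound 3 `COc1ccc(-c2c(-c3ccc(OC)cc3)n(Cc3ccccc3)c3ncn([C@H]4CC[C@H](O)CC4)c(=N)c23)cc1`: in this assay compound 3 gives 196 10^-6 cm/s.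

Among the measured compounds shown here, compound 3 therefore holds the only actual number among the three; the other two sit at the limit of > 1000 10^-6 cm/s in this assay, at which 2 of the 3 values shown sit. The next compound, compound 4 `COc1ccc(-c2c(-c3ccc(OC)cc3)n(Cc3ccccc3)c3ncn(CCO)c(=N)c23)cc1`, differs from compound 3 in one place: 2-hydroxyethyl in place of 4-hydroxycyclohexyl on an aromatic nitrogen. For the measured compounds named here, two measured steps bear on this. The move from a 3-hydroxypropyl chain to the 4-hydroxycyclohexyl ring gave an at least 5.1-fold lower number from compound 1 to compound 3 (0.70 log units; beyond the scatter), so the reverse kind of move, back to a short hydroxyalkyl chain, points upward. The methyl-to-hydrogen step gave an at least 5.1-fold lower number from compound 2 to compound 3 (0.70 log units; beyond the scatter), which again marks the 4-hydroxycyclohexyl compound as the low one. The step that the two limits leave unreadable from compound 1 to compound 2 gives no usable size. In this assay a rise of about a 4.1-fold higher number from compound 3 to compound 4 (0.61 log units; beyond the scatter) is therefore expected. For compound 4 the estimate in this assay is 800 10^-6 cm/s, expected to fall between 300 10^-6 cm/s and 2000 10^-6 cm/s, with a fair chance that only a limit is reported.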

Compound 4, apparent permeability: > 1000 10^-6 cm/s
Compound 4 ended at the assay's limit; the forecaster's own chance of this, stated with the estimate: 45%; middle value at least 1.2-fold (0.09 log units) from the limit.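

In this assay, among the compounds shown here, putting 2-hydroxyethyl in place of 4-hydroxycyclohexyl on the aromatic nitrogen gives an at least 5.1-fold higher number from compound 3 to compound 4 (0.70 log units; beyond the scatter), so a change at this position can also raise the read-out beyond the scatter, where the earlier steps that could be read showed only a fall. Both groups carry 1 hydrogen-bond donor and 1 hydrogen-bond acceptor and no net charge, so this step goes with the loss of the six-membered non-aromatic ring and its 2 defined stereocentres, and with the drop from 7 heavy atoms to 3, and not with any change in those counts. The ring alone does not go with a low number, however: compound 2, which keeps it as 4-methoxycyclohexyl, gives > 1000 10^-6 cm/s, a limit of the assay and not a number.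

The steps among the other compounds cannot be read, and how far these compounds differ from one another stays hidden: the limit of > 1000 10^-6 cm/s in this assay, at which 3 of the 4 values shown sit.

From the compounds shown here alone, it also stays open how this position would respond to an amine or a carboxylic acid at the end of the chain in place of the hydroxy group.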